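A few compounds are considered here, and "the series" means these few. Any claim that something is new, unique, unknown or untested is made for them only; others in the source may bear on it.

Measured compounds:
compound 1 `COc1cc(C2=NN(C(=O)c3ccccc3)C(c3ccccc3)C2)ccc1O` gives 4250 nM
compound 2 `COc1cc(C2=NN(C(=S)Nc3ccccc3)C(c3ccccc3)C2)ccc1O` gives 550 nM
compound 3 `CCOC(=O)N1N=C(c2ccc(O)c(OC)c2)CC1c1ccccc1` gives 440 nM

These three share one core and differ only in the group on the amine nitrogen in the ring. All were tested in an assay on isolated protein for inhibition of Amine oxidase [flavin-containing] A (Homo sapiens), read by Amplex Red, with a stated time of 15 min; a lower number here means a stronger inhibitor, a higher number a weaker inhibitor. Compound 3 holds the lowest number of the three, but the step of a 1.3-fold lower number from compound 2 to compound 3 (0.10 log units; within the scatter) is within the scatter, so compound 2 and compound 3 cannot be told apart; only compound 1 stands clearly apart, as the step of a 9.7-fold lower number from compound 1 to compound 3 (0.98 log units; beyond the scatter) shows.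

Compound 4 `COc1cc(C2=NN(C(C)=O)C(c3ccccc3)C2)ccc1O` has not yet been measured. Its change from compound 3 is methyl in place of ethoxy on a carbonyl carbon. Within the data shown here, no measured step swaps ethoxy for methyl, so no direct guide exists. The step that bears closest is a 9.7-fold lower number from compound 1 to compound 3 (0.98 log units; beyond the scatter), which shows that exchanging the group on this carbonyl carbon can move the number by a modest amount; the step of a 7.7-fold lower number from compound 1 to compound 2 (0.89 log units; beyond the scatter) shows a similar size for a change at the same ring nitrogen. For compound 4 a modest rise in the number is therefore expected, a 2.7-fold higher number from compound 3 to compound 4 (0.44 log units; beyond the scatter), with wide uncertainty. The estimate for compound 4 is 1200 nM, within a range from 350 nM to 4500 nM.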

Compound 4, inhibition constant: 3870 nM
The estimate for compound 4 lay 3.2-fold (0.51 log units) below the measured number; the measured number falls inside the stated range.
By their numbers in this assay, from the lowest: compounds 3 and 2 (each within the scatter of the next); then compounds 4 and 1 (each within the scatter of the next).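

Replacing ethoxy with methyl on this carbonyl carbon has a clear effect (an 8.8-fold higher number from compound 3 to compound 4 (0.94 log units; beyond the scatter)), whereas methyl and phenyl at this carbon cannot be told apart (a 1.1-fold lower number from compound 1 to compound 4 (0.04 log units; within the scatter)). So on this evidence the low number belongs to the ethoxy compound rather than to any group on the carbonyl carbon, and acetyl also falls clearly short of the much larger thiocarbonyl-bearing group of compound 2 on the ring nitrogen (a 7.0-fold higher number from compound 2 to compound 4 (0.85 log units; beyond the scatter)). Nothing measured here explains why ethoxy differs from methyl and phenyl. The compounds shown leave open whether the oxygen attached to the carbonyl carbon or the length of the chain matters more. A methoxy group or a propyl group on that carbon would help separate the two.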